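The source may hold more compounds than are shown below. What is called first, only, known or untested is meant among the compounds shown, and "the series" means these compounds.

Measured so far:
compound 1, `CCOC(=O)C1CCN(C(=O)CN2CN(c3ccccc3)C3(CCN(C(=O)c4ccc(C5CCCCC5)cc4)CC3)C2=O)CC1`, 900 nM
compound 2, `CC(C)(C)c1ccc(C(=O)N2CCC3(CC2)C(=O)N(CC(=O)NCCCCCNS(C)(=O)=O)CN3c2ccccc2)cc1`, 5500 nM

Of the compounds shown here, two have been measured in an assay on HEK293 cells for displacement of a labelled ligand from NPC1-like intracellular cholesterol transporter 1 (Homo sapiens); a higher number here means a weaker inhibitor, a lower number a stronger inhibitor. Compound 1 `CCOC(=O)C1CCN(C(=O)CN2CN(c3ccccc3)C3(CCN(C(=O)c4ccc(C5CCCCC5)cc4)CC3)C2=O)CC1` gives 900 nM. Compound 2 `CC(C)(C)c1ccc(C(=O)N2CCC3(CC2)C(=O)N(CC(=O)NCCCCCNS(C)(=O)=O)CN3c2ccccc2)cc1` gives 5500 nM, the higher of the two numbers, and the gap between compound 2 and compound 1 lies beyond the scatter of repeated measurements. The two differ in several places at once, so nothing in these numbers can be tied to any single change.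

Compound 3 `CC(C)(C)c1ccc(C(=O)N2CCC3(CC2)C(=O)N(CC(=O)NCCCCN)CN3c2ccccc2)cc1` is the next compound to be measured in this assay. It differs from compound 2 in one place: amino in place of (methanesulfonamido)methyl on a saturated chain carbon, four bonds along the chain from an amide-type nitrogen. The chain is shortened and its terminal group replaced. Going by the values given here, no pair of measured compounds shows what this change does, so there is no step to lean on. Compound 3 is therefore expected to stay near compound 2, with the step of a 1.2-fold lower number from compound 2 to compound 3 (0.09 log units; within the scatter) expected to be small and not clearly beyond the scatter in either direction. The estimate for compound 3 is 4500 nM, with a range from 1500 nM to 13000 nM.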

Compound 3, half-maximal inhibitory concentration: 14500 nM
The estimate for compound 3 lay 3.2-fold (0.51 log units) below the measured number, outside the stated range (above it).
By their numbers in this assay, from the lowest: compound 1; then compound 2; then compound 3.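

In this assay the far end of this chain turns out not to be a neutral place: amino in place of (methanesulfonamido)methyl, on a saturated chain carbon, four bonds along the chain from an amide-type nitrogen, gives a 2.6-fold higher number from compound 2 to compound 3 (0.42 log units; beyond the scatter) and so a modest weakening. Going by these compounds alone, this is the first comparison here in which only one place differs, and it puts the compound with the methanesulfonamide-bearing chain on the stronger side of the pair, so the core and the tert-butyl-bearing benzoyl group alone do not fix the number. No measurement shown here accounts for the step.

The change shortens the chain and replaces its end group together, so the compounds shown cannot say which of the two matters, or whether both do. An amine on the longer chain of compound 2 or a methanesulfonamide on the shorter chain of compound 3 would separate the two, while a carboxylic acid or a still longer chain at this end remains an open question.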